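Side-chain exchange on the ring nitrogen of compound 1

A few compounds are considered here, and "the series" means these few. Any claim that something is new, unique, unknown or untested is made for them only; others in the source may bear on it.

Measured so far:
compound 1, `COC(CCn1cnc2c(NCc3ccc(C(=O)Nc4ccccc4N)cc3)nc(Cl)nc21)OC`, in a functional assay on NCI-H460 cells (Homo sapiens) for antiproliferative activity, read by CCK-8 assay, with a stated time of 72 h, tested at 8 uM; on this read-out lower numbers stand for a weaker effect and higher numbers for a stronger effect at the one concentration tested: 51.2%
compound 2, `CCCCn1cnc2c(Nc3cccc(Cl)c3)nc(NCOCc3ccc(/C=C/C(=O)Nc4ccccc4N)cc3)nc21`, in this assay: 51.1%

Compound 1 stands highest of the two numbers, but compound 2 sits within the usual scatter of it, so no order between the two can be read from these values. Among the compounds with values here, no pair of measured compounds differs in only one place, so no single-change step is known in this set.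

The next compound is compound 3, `CCC(C)n1cnc2c(NCc3ccc(C(=O)Nc4ccccc4N)cc3)nc(Cl)nc21`. It differs from compound 1 in one place: sec-butyl in place of 3,3-dimethoxypropyl on an aromatic nitrogen. The exchange is an open one, as nothing measured here bears on the side chain at that aromatic nitrogen, and the two measured compounds give no guide to its weight. With that in mind the expected step in this assay from compound 1 to compound 3 is a number 3.2 percentage points lower from compound 1 to compound 3 (within the scatter), that is none beyond the scatter, with a wide spread either way. For compound 3 the estimate in this assay is 48%, ranging from 30% to 65%.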

Compound 3, a percentage reported as inhibition, at one concentration (the size of the read-out at that concentration, not a potency): 67.7%
Compound 3: middle estimate off by 19.7 percentage points, on the low side, and the stated range ends below it.
By their numbers in this assay, from the lowest: compounds 2 and 1 (each within the scatter of the next); then compound 3.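

In this assay, within the data shown here, the side chain on the aromatic nitrogen proves to be a position that can move the read-out: sec-butyl in place of 3,3-dimethoxypropyl gives a number 16.5 percentage points higher from compound 1 to compound 3 (beyond the scatter), the first single-change step in the set. The change replaces a chain of 7 heavy atoms with 2 hydrogen-bond acceptors by an all-carbon branched group of 4 heavy atoms with none, so this one step bundles together shorter length, branching and the loss of both oxygens without separating them. Nothing available here accounts for the higher number.

Still open, from the compounds shown here alone, is which of those differences matters, and whether a 3-methoxypropyl chain, an isopropyl group or a cyclopentyl ring on the same nitrogen would stay level with compound 3 at 67.7% or fall back towards compound 1 at 51.2%. The number for each compound also comes from one concentration, so it tells only of a stronger or weaker effect at that concentration.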